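Swapping furan for thiophene on compound 2

This account rests on a few compounds, and the source may have more. Where it says the series, first, only, none or still open, it means among the compounds named here.

In a functional assay on HCT-116 cells (Homo sapiens), read by MTT assay, with a stated time of 72 h (on this read-out higher numbers stand for weaker inhibition and lower numbers for stronger inhibition), compound 1 (`CNc1ncnc2c1c(-c1ccco1)cn2[C@@H]1O[C@H](CO)[C@@H](O)[C@H]1O`) gives 230 nM. Compound 2 (`Nc1nc(N)c2c(-c3ccco3)cn([C@@H]3O[C@H](CO)[C@@H](O)[C@H]3O)c2n1`) gives no number, only a limit of the assay, > 20000 nM. Compound 3 (`Nc1nc(N)c2c(-c3cccs3)cn([C@@H]3O[C@H](CO)[C@@H](O)[C@H]3O)c2n1`) keeps the core of compound 2 and carries thiophen-2-yl in place of furan-2-yl on an aromatic carbon. Within the data shown here, no measured pair isolates this exchange, so its size cannot be read from the data. In this assay, the exchange is expected to bring no step beyond the scatter, and neither direction is favoured. The only anchor for this expectation is compound 2, whose reading of > 20000 nM is a limit. A limit is therefore also the likeliest report for compound 3. The estimated change is a number no higher from compound 2 to compound 3 (the limit leaves the size open). For compound 3, the estimated value is 20000 nM, with an expected range from 6000 nM to 30000 nM.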

Compound 3, half-maximal inhibitory concentration: > 20000 nM
Compound 3 was reported as a limit; the forecaster's own chance of this, stated with the estimate: 70%; the middle value sits exactly at the limit.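

No step can be read from compound 2 to compound 3 in this assay, since both readings are limits and not numbers: the limit of > 20000 nM in this assay, at which 2 of the 3 values shown sit. Still open, on these data alone, is whether thiophen-2-yl in place of furan-2-yl on an aromatic carbon changes the read-out at all on the shared core.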